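This account rests on a few compounds, and the source may have more. Where it says the series, first, only, none or still open, it means among the compounds named here.

Measured so far:
compound 1, `CC(C)(C)c1ccc(CNC(=O)NC(=O)CCl)cc1`, 7100 nM
compound 2, `CCNC(=O)NCc1ccc(C(C)(C)C)cc1`, > 100000 nM
compound 3, `CC(C)(C)c1ccc(NC(=O)CCCCl)cc1`, > 100000 nM

In a functional assay on HT-29 cells (Homo sapiens) for antiproliferative activity, with a stated time of 48 h (a lower number here means a stronger inhibitor, a higher number a weaker inhibitor), compound 1 gives 7100 nM. For compound 2 the result is only a limit of the assay, > 100000 nM. For compound 3 likewise only a limit is recorded, > 100000 nM. Within the data shown here, compound 2 therefore stands at the limit, as does compound 3; compound 1 is the only compound of the three with a number, and an at least 14-fold higher number from compound 1 to compound 2 (1.14 log units; beyond the scatter) is the one measured step, a large loss in this assay when the (chloromethyl)carbonyl on the amide-type nitrogen is exchanged for ethyl. The unmeasured compound 4, `CC(C)(C)c1ccc(CNC(=O)CCCCl)cc1`, is reached from compound 2 by 3-chloropropyl in place of ethylamino on a carbonyl carbon; cut one bond further out, ethylcarbamoyl becomes (3-chloropropyl)carbonyl. Compound 3 carries the same (3-chloropropyl)carbonyl on an anilide nitrogen and sits at the limit (the limit of > 100000 nM in this assay, at which 2 of the 3 values shown sit), which counts against a clear gain, whereas the step from compound 1 to compound 2 shows that a chloroalkylcarbonyl group can matter. The expected step of an at least 2.0-fold lower number from compound 2 to compound 4 (0.30 log units; that floor lies within the scatter) is therefore a modest one toward a lower number, with wide uncertainty. Compound 4 is expected to give about 50000 nM, within 10000 nM to 200000 nM.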

Compound 4, half-maximal inhibitory concentration: 72000 nM
For compound 4 the middle estimate is 1.4-fold (0.16 log units) below the measured one; measured number inside the range.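

In this assay, 3-chloropropyl in place of ethylamino on a carbonyl carbon gives an at least 1.3-fold lower number from compound 2 to compound 4 (0.14 log units; that floor lies within the scatter), so this exchange shows no gain that can be separated from the scatter. Compound 2 is recorded only as a limit, so this step has only a floor: the limit of > 100000 nM in this assay, at which 2 of the 4 values shown sit. A 3-chloropropyl chain on this carbonyl carbon also does not match ((chloromethyl)carbonyl)amino, as the exchange gives a 10-fold higher number from compound 1 to compound 4 (1.01 log units; beyond the scatter).

The compounds shown leave open whether the chlorine or the additional carbonyl of compound 1 matters more for its value in this assay. An acetyl group on the same amide-type nitrogen, which keeps the carbonyl without chlorine, would separate these two features, while a longer chloroalkyl chain would test the length of the group.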